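Replacing the Amine Substituent on the Shared Core

A few compounds are considered here, and "the series" means these few. Any claim that something is new, unique, unknown or untested is made for them only; others in the source may bear on it.

Compound 1: `O=C(CCc1ccc(C(F)(F)F)cc1)Nc1ccc2nc(N3CC4CC3CN4)ccc2c1`, 210 nM
Compound 2: `CN(c1ccc2cc(NC(=O)CCc3ccc(C(F)(F)F)cc3)ccc2n1)C1CCCCC1`, 18 nM

Within the data shown here, in an assay on isolated protein for displacement of a labelled ligand from melanin-concentrating hormone receptor 1 (Homo sapiens) (a higher number here means a weaker inhibitor, a lower number a stronger inhibitor), compound 2 gives 18 nM, the lowest of the two numbers so far; compound 1 gives 210 nM. Among the measured compounds shown here, the single measured step, a 12-fold lower number from compound 1 to compound 2 (1.07 log units; beyond the scatter), shows that the amine attached to the shared core can shift the read-out a great deal.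

Compound 3 `CC1CCN(c2ccc3cc(NC(=O)CCc4ccc(C(F)(F)F)cc4)ccc3n2)C1` differs from compound 2 by 3-methylpyrrolidin-1-yl in place of cyclohexyl(methyl)amino on an aromatic carbon. For the measured compounds named here, the step of a 12-fold lower number from compound 1 to compound 2 (1.07 log units; beyond the scatter) bears on this only loosely, since the group entering compound 3 is neither of the two groups compared there; no measured pair shows a direct parallel. Given how strongly that one change moved the number, a moderate rise is expected rather than none, with wide uncertainty. For compound 3 the estimate is 50 nM, within 12 nM to 200 nM, which means an expected step of a 2.8-fold higher number from compound 2 to compound 3 (0.44 log units; beyond the scatter).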

Compound 3, half-maximal inhibitory concentration: 2 nM
Compound 3: middle estimate off by 25-fold (1.40 log units), on the high side, outside the stated range (below it).
By their numbers in this assay, from the lowest: compound 3; then compound 2; then compound 1.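

In this assay, the step of a 9.0-fold lower number from compound 2 to compound 3 (0.95 log units; beyond the scatter) shows that the large cyclohexyl(methyl)amino group is not needed on this aromatic carbon next to the ring nitrogen: the smaller 3-methylpyrrolidin-1-yl group, with a single ring that includes the nitrogen, gives a clearly lower number. The wider step of a 110-fold lower number from compound 1 to compound 3 (2.02 log units; beyond the scatter) shows that changing this one group alone can cover a very large range, well beyond what the first pair revealed. Among these compounds, no measurement here explains why this change lowers the number so far.

From the compounds shown here alone, how much the methyl group itself contributes remains open, and a comparison with plain pyrrolidin-1-yl would address that. Going by these compounds, whether piperidin-1-yl or morpholin-4-yl would match 3-methylpyrrolidin-1-yl on this carbon also remains open.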